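Methoxy for methylsulfonyl on the benzoyl group

This account rests on a few compounds, and the source may have more. Where it says the series, first, only, none or still open, it means among the compounds named here.

Measured compounds:
compound 1, `COc1ccc(C(=O)N2CCC(n3cncc3-c3ccc(OS(=O)(=O)c4cccc(C#N)c4)cc3)CC2)cc1`: 312 nM
compound 2, `CS(=O)(=O)c1ccc(C(=O)N2CCC(n3cncc3-c3ccc(OS(=O)(=O)c4cccc(C(=O)NC5CC5)c4)cc3)CC2)cc1`: 400 nM

In an assay on HEK293 cells for antagonist activity at P2X purinoceptor 7 (Homo sapiens), read by fluorescence, with a stated time of 2 h (a higher number here means a weaker inhibitor, a lower number a stronger inhibitor), compound 1 gives 312 nM and compound 2 gives 400 nM. Compound 2 stands alongside compound 1 on these numbers; the gap between them lies within the scatter. Compound 3 `COc1ccc(C(=O)N2CCC(n3cncc3-c3ccc(OS(=O)(=O)c4cccc(C(=O)NC5CC5)c4)cc3)CC2)cc1` differs from compound 2 by methoxy in place of methylsulfonyl on an aromatic carbon. Among the measured compounds shown here, no measured pair shows this single change, and the two measured values lie close together, so a step beyond the scatter is not expected; the expected step is a 1.1-fold lower number from compound 2 to compound 3 (0.06 log units; within the scatter). Compound 3 is estimated at 350 nM, with a range from 150 nM to 800 nM.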

Compound 3, half-maximal inhibitory concentration: 244 nM
Compound 3: middle estimate off by 1.4-fold (0.16 log units), on the high side, and the stated range covers the measured number.
By their numbers in this assay, from the lowest: compounds 3, 1 and 2 (each within the scatter of the next).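

In this assay 4-methoxyphenyl in place of 4-(methylsulfonyl)phenyl gives a 1.6-fold lower number from compound 2 to compound 3 (0.21 log units; within the scatter) and so shows, as a single change, that these two groups cannot be told apart at this position. Cyclopropylcarbamoyl in place of cyano, a second single change, gives a 1.3-fold lower number from compound 1 to compound 3 (0.11 log units; within the scatter) and likewise separates nothing. No evidence is at hand that bears on these results. The compounds shown leave open whether an amine or a carboxylic acid at this aromatic carbon would also stay within the scatter, and whether any group there would produce a step beyond it.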